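Phenyl in place of cyclobutyl: notes on compound 3

The compounds below may be only part of what the source reports. "The series", "measured", "known", "first", "only" and "open" are said of these compounds alone.

Measured in an ADME assay on microsomes from liver (Homo sapiens) for metabolic stability, read by LC-MS, using NADPH, with a stated time of 45 min, tested at 3 uM; a lower number here means that the compound disappears faster, a higher number that the compound lasts longer:
- compound 1 `C1CCC(C(CC2CCCCN2)C2CCC2)CC1`: > 3.33 h (a limit)
- compound 2 `C1CCC(CC(C2CCCC2)C2CCC2)NC1`: 0.85 h

Compound 1 gives > 3.33 h, which is a limit and not a number. Its standing in the series is the limit of > 3.33 h in this assay, at which 1 of the 2 values shown sits.

Compound 3 `c1ccc(C(CC2CCCCN2)C2CCCCC2)cc1` has not yet been measured in this assay. Its difference from compound 1 is phenyl in place of cyclobutyl on a saturated chain carbon bound to a saturated chain carbon and a saturated ring carbon. The new ring is aromatic, and the other ring on that carbon, cyclohexyl, stays.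

For the measured compounds named here, one measured step bears on this change, and only indirectly. an at least 3.9-fold lower number from compound 1 to compound 2 (0.59 log units; beyond the scatter) is a swap of the other ring on the same carbon, cyclopentyl in place of cyclohexyl. That step shows that a ring change on this carbon can lower the number beyond the scatter. Going by the values given here, no measured step covers phenyl, so the size remains uncertain. A lower number of modest size is expected, and a reading at the limit remains possible. The expected change is an at least 1.5-fold lower number from compound 1 to compound 3 (0.18 log units; that floor lies within the scatter). For compound 3 the estimated half-life is 2.2 h, with an expected range from 0.7 h to 6 h.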

Compound 3, half-life: 0.933 h
The estimate for compound 3 lay 2.4-fold (0.37 log units) above the measured number; the range from low to high includes it.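

In this assay, phenyl in place of cyclobutyl gives an at least 3.5-fold lower number from compound 1 to compound 3 (0.55 log units; beyond the scatter), which shows that the cyclobutyl position on this saturated chain carbon is sensitive too, and not only the cyclohexyl position. Alongside an at least 3.9-fold lower number from compound 1 to compound 2 (0.59 log units; beyond the scatter), a lower number beyond the scatter has now been seen for a change at each of the two rings on this carbon, with a non-aromatic ring entering in one case and an aromatic ring in the other. Both steps are floors rather than sizes, since each starts from a value that is a limit: the limit of > 3.33 h in this assay, at which 1 of the 3 values shown sits.

Still open, from the compounds shown here alone, is how far the half-life of compound 1 lies past its limit, so the true size of each step is unknown, and compound 2 and compound 3 differ in more than one place and cannot be set against each other directly. Also open, going by these compounds, is whether a pyridyl ring or a fluorine-bearing phenyl ring in place of cyclobutyl would read differently from phenyl, and whether a simple methyl group there would keep the number of compound 1.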